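This account rests on a few compounds, and the source may have more. Where it says the series, first, only, none or still open, it means among the compounds named here.

Four compounds are compared here, all built around a closely related amide. In a functional assay on MCF7 cells (Homo sapiens) for cytotoxicity, read by trypan blue exclusion, with a stated time of 48 h (on this read-out higher numbers stand for weaker inhibition and lower numbers for stronger inhibition), compound 1, `Cc1ccc(-c2csc(NC(=O)COc3ccccc3C(C)C)n2)cc1`, gives 49000 nM. Compound 2, `CC(C)c1ccccc1OCC(=O)Nc1nc(-c2ccc(Br)cc2)cs1`, differs from compound 1 in one place, namely (bromo in place of methyl on an aromatic carbon), and in this assay compound 2 gives 43500 nM. The resulting step, a 1.1-fold lower number from compound 1 to compound 2 (0.05 log units; within the scatter), is too small to count as a real change. Compound 3, `Cc1ccc(OCC(=O)Nc2nc(-c3ccc(C)cc3)cs2)cc1`, rests on another core; the difference between the core of compound 1 and the core of compound 3 is not broken down here. In this assay compound 3 gives 41400 nM, a number within the scatter of both compound 1 and compound 2. Compound 4, `Cc1ccc(OCC(=O)Nc2nc(-c3ccc(Br)cc3)cs2)cc1`, stands to compound 3 as compound 2 stands to compound 1: the change is bromo in place of methyl on an aromatic carbon, the same change at the same kind of place. Since that change gave a 1.1-fold lower number from compound 1 to compound 2 (0.05 log units; within the scatter), the step is expected to be equally small, namely a 1.1-fold lower number from compound 3 to compound 4 (0.03 log units; within the scatter). Compound 4 is therefore expected to give about 39000 nM in this assay, most likely between 20000 nM and 75000 nM.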

Compound 4, half-maximal inhibitory concentration: 52400 nM
Compound 4: middle estimate off by 1.3-fold (0.13 log units), on the low side; the measured number falls inside the stated range.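

In this assay, putting bromo in place of methyl on the core of compound 3 gives a 1.3-fold higher number from compound 3 to compound 4 (0.10 log units; within the scatter), so this step, like the earlier one on the core of compound 1, is too small to count as a real change. Set side by side, the two steps do not differ by more than ordinary repeat measurements would: the same change on two cores in this assay, a 1.1-fold lower number (0.05 log units; within the scatter) from compound 1 to compound 2 and a 1.3-fold higher number (0.10 log units; within the scatter) from compound 3 to compound 4, 1.4-fold (0.15 log units) apart, within the scatter of two such steps. For the compounds shown here, this shows that going from 4-methylphenyl to 4-bromophenyl made no measurable difference on either of these two cores, but with only two pairs and no real change in either, it does not show that the change would also make no difference on other cores, nor that a real effect would carry over from one core to another.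

The compounds shown leave open whether a different group at this place, such as an amine or a carboxylic acid, would move the number beyond the scatter. They also leave open what a longer chain at this place would do.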